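A few compounds are considered here, and "the series" means these few. Any claim that something is new, unique, unknown or untested is made for them only; others in the source may bear on it.

Measured compounds in an assay on isolated protein for inhibition of extracellular serine/threonine protein kinase FAM20C (Homo sapiens), read by malachite green, tested at 10 uM, in the presence of a further agent that is not named here; a higher number here means more inhibition at the concentration tested (going by the name of the read-out), a lower number less inhibition:
compound 1 `COc1ccc(Nc2ccnc(Nc3ccc(NS(=O)(=O)c4ccc(OC)cc4)cc3)n2)cc1` gives 25%
compound 2 `COc1ccc(Nc2ccnc(Nc3ccc(NS(=O)(=O)c4ccc(C(F)(F)F)cc4)cc3)n2)cc1` gives 18%
compound 3 `COc1ccc(S(=O)(=O)Nc2ccc(Nc3nccc(Nc4cc(OC)c(OC)c(OC)c4)n3)cc2)cc1` gives 68%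

Compound 1 stands second highest of the three numbers in this assay. Its nearest neighbour is compound 2, a number 7 percentage points lower from compound 1 to compound 2 (within the scatter); its furthest is compound 3, a number 43 percentage points higher from compound 1 to compound 3 (beyond the scatter).

Compound 4 `COc1ccc(S(=O)(=O)Nc2ccc(Nc3nccc(-c4ccccc4)n3)cc2)cc1` is not yet measured. It differs from compound 1 in one place: phenyl in place of (4-methoxyphenyl)amino on an aromatic carbon

Within the data shown here, no measured step makes this exact change. The step of a number 43 percentage points higher from compound 1 to compound 3 (beyond the scatter) touches the same region of the molecule and shows that this assay responds strongly to what sits there, while a number 7 percentage points lower from compound 1 to compound 2 (within the scatter) concerns a different position and stayed within the scatter. Removing the (4-methoxyphenyl)amino group altogether is therefore a change of unknown direction, and the expectation for compound 4 must be wide. The estimated step is a number 5 percentage points lower from compound 1 to compound 4 (within the scatter), meaning compound 4 is expected to give 20%, in a range from 2% to 50%.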

Compound 4, a percentage reported as inhibition, at one concentration (the size of the read-out at that concentration, not a potency): 10%
For compound 4 the middle estimate is 10 percentage points above the measured one, and the stated range covers the measured number.
By their numbers in this assay, from the lowest: compounds 4, 2 and 1 (each within the scatter of the next, the first and the last beyond it); then compound 3.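

In this assay, swapping the (4-methoxyphenyl)amino group for phenyl gives a number 15 percentage points lower from compound 1 to compound 4 (beyond the scatter), and this is the first change shown that removes the linking nitrogen, so the ring sits directly on the aromatic carbon of the core. Set beside a number 43 percentage points higher from compound 1 to compound 3 (beyond the scatter), it shows that changes at this one position can move the read-out either up or down by more than the scatter. No measurement at hand explains the fall.

The nitrogen and the methoxy leave in a single change, so the share of each in the step cannot be told apart. A plain phenylamino group, or a 4-methoxyphenyl attached directly to the carbon, would separate the two, and a simple amine or a morpholine would test whether an aromatic ring is needed here at all.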